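This account rests on a few compounds, and the source may have more. Where it says the series, first, only, none or still open, it means among the compounds named here.

Measured so far:
compound 1 `Cc1cccc(C(=O)Nc2nn[nH]n2)n1`, 46%
compound 2 `CC(C)c1ccnc(C(=O)Nc2nn[nH]n2)c1`, 34%
compound 3 `O=C(Nc1nn[nH]n1)c1cccnc1`, 4%

In a functional assay on the whole organism for inhibition, with Rattus norvegicus as the target, at a dose of 3 mg/kg by the oral route (on this read-out higher numbers stand for a stronger effect at the one dose given and lower numbers for a weaker effect), compound 1 gives 46%, the highest of the three numbers. Compound 2 gives 34%, a number that lies beyond the scatter from that of compound 1, and compound 3 gives 4%, the number furthest from that of compound 1. Three compounds with three different substitution patterns on the shared core allow no pattern to be drawn; only compound 1 carries a group on the position now under consideration.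

Compound 4 `O=C(Nc1nn[nH]n1)c1cccc(Cl)n1` differs from compound 1 by chloro in place of methyl on an aromatic carbon. Going by the values given here, no pair among the measured compounds shows a change of this kind, so no size can be read from the data. The step from compound 1 to compound 4 in this assay is expected to be a number 6 percentage points lower from compound 1 to compound 4 (within the scatter), a modest decrease or none beyond the scatter. Compound 4 is therefore estimated at 40%, with a range from 20% to 60%.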

Compound 4, a percentage reported as inhibition, in the whole organism at one dose (the size of the read-out at that dose, not a potency): 18%
Compound 4: the middle estimate sits 22 percentage points above what was measured; the whole stated range lies above it.
By their numbers in this assay, from the lowest: compound 3; then compound 4; then compound 2; then compound 1.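

Chloro in place of methyl on this aromatic carbon next to the ring nitrogen gives, in this assay, a number 28 percentage points lower from compound 1 to compound 4 (beyond the scatter), the first step that can be read at this position. The position is thus not indifferent to the group it carries, and for this one exchange methyl gives the higher number. Nothing shown accounts for this step.

Going by these compounds, whether ethyl, methoxy or an amine at this position would match or exceed compound 1 stays open. So does whether this step would hold with other groups elsewhere on the shared core.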